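The source may hold more compounds than are shown below. What is called first, only, known or untested is meant among the compounds shown, and "the series" means these compounds.

Measured compounds:
Compound 1 `CC(C)(C)c1ccc(CNCCCNS(=O)(=O)c2cc(C(F)(F)F)cc(C(F)(F)F)c2)cc1` gives 2500 nM in a functional assay on PANC-1 cells (Homo sapiens) for inhibition, read by MTT assay, with a stated time of 72 h; a higher number here means a weaker inhibitor of growth, a lower number a stronger inhibitor of growth.
Compound 2 `O=S(=O)(NCCCCNCc1ccc(Br)cc1)c1cc(C(F)(F)F)cc(C(F)(F)F)c1` gives 2200 nM in this assay.
Compound 3 `COc1ccc(CNCCCNS(=O)(=O)c2cc(C(F)(F)F)cc(C(F)(F)F)c2)cc1` gives 11000 nM in this assay.

Compound 2 has the lowest number of the three, though compound 1 sits within the scatter of it, and only compound 3 lies clearly higher. Compound 4 `O=S(=O)(NCCCNCc1ccc(Cl)cc1)c1cc(C(F)(F)F)cc(C(F)(F)F)c1` differs from compound 2 by (4-chlorobenzyl)amino in place of ((4-bromobenzyl)amino)methyl on a saturated chain carbon, three bonds along the chain from a sulfonamide nitrogen. Going by the values given here, no measured step tests the halogen swap directly. The chain shortening is touched by comparing a 5.0-fold higher number from compound 2 to compound 3 (0.70 log units; beyond the scatter) with a 4.4-fold higher number from compound 1 to compound 3 (0.64 log units; beyond the scatter): the two steps are close, so the shorter chain by itself seems to matter little. A change within the scatter is therefore expected, a 1.1-fold higher number from compound 2 to compound 4 (0.06 log units; within the scatter). Compound 4 is estimated at 2500 nM, with a range from 1200 nM to 6000 nM.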

Compound 4, concentration for 50% growth inhibition: 4900 nM
For compound 4 the middle estimate is 2.0-fold (0.29 log units) below the measured one; the measured number falls inside the stated range.
By their numbers in this assay, from the lowest: compounds 2, 1 and 4 (each within the scatter of the next, the first and the last beyond it); then compound 3.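

Replacing ((4-bromobenzyl)amino)methyl with (4-chlorobenzyl)amino on the saturated chain carbon weakens growth inhibition in this assay (a 2.2-fold higher number from compound 2 to compound 4 (0.35 log units; beyond the scatter)), so this change has a modest but real effect. On the aromatic carbon, chloro gives stronger inhibition than methoxy (a 2.2-fold lower number from compound 3 to compound 4 (0.35 log units; beyond the scatter)), whereas chloro in place of tert-butyl shows no clear change (a 2.0-fold higher number from compound 1 to compound 4 (0.29 log units; within the scatter)). Nothing measured here gives a reason for these steps. From the compounds shown here alone, it remains open whether the halogen or the chain length drives the first step, and how a nitrile or a carboxylic acid on that aromatic carbon would compare.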